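The compounds below may be only part of what the source reports. "The series", "measured", "known", "first", "only" and "open" are said of these compounds alone.

Measured so far in a functional assay on HepG2 cells (Homo sapiens) for cytotoxicity, read by MTT assay, with a stated time of 24 h; a higher number here means a weaker inhibitor, a lower number a stronger inhibitor:
compound 1 `CN1C/C(=C\c2ccncc2)C(=O)/C(=C/c2ccccc2F)C1` gives 4600 nM
compound 2 `CN1C/C(=C\c2ccncc2)C(=O)/C(=C/c2ccc(F)cc2Br)C1` gives 9200 nM

On these two numbers compound 1 carries the lowest, with compound 2 nearest to it; the difference a 2.0-fold higher number from compound 1 to compound 2 (0.30 log units; within the scatter) is within the scatter, so no order between them is claimed.

Compound 3 `O=C1/C(=C/c2ccncc2)CN(S(=O)(=O)c2ccc(Br)cc2)C/C1=C\c1ccccc1F` is not yet measured. Relative to compound 1 the change is (4-bromophenyl)sulfonyl in place of methyl on an amine nitrogen in a ring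

Among the compounds with values here, the only measured step, from compound 1 to compound 2, alters the aryl group on the double-bonded chain carbon and leaves the amine nitrogen in the ring untouched, so it gives no guide to a swap at that nitrogen. Within the data shown here, no measured compound carries anything other than methyl there. The expectation therefore rests on compound 1 alone, and the step is expected to be a 1.5-fold lower number from compound 1 to compound 3 (0.19 log units; within the scatter), with wide uncertainty in either direction.

Compound 3 is expected to give about 3000 nM in this assay, estimated to lie between 700 nM and 13000 nM.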

Compound 3, half-maximal inhibitory concentration: 9300 nM
Estimate against measurement, compound 3: 3.1-fold (0.49 log units) below; the range from low to high includes it.
By their numbers in this assay, from the lowest: compounds 1, 2 and 3 (each within the scatter of the next, the first and the last beyond it).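

In this assay, within the data shown here, replacing methyl with (4-bromophenyl)sulfonyl on the amine nitrogen in a ring gives a 2.0-fold higher number from compound 1 to compound 3 (0.31 log units; beyond the scatter), the first reading at this position. The step is modest for a change that adds an aromatic ring and hydrogen-bond acceptors, so on this single pair the position tolerates a much larger group without a large loss in this read-out. Nothing on hand accounts for the size of this step.

The compounds shown leave open whether the step comes from the sulfonyl link or from the 4-bromophenyl ring, and how a benzyl or acetyl group on the same nitrogen would read. Also open, from the compounds shown here alone, is whether the step would keep its size with 2-bromo-4-fluorophenyl in place of 2-fluorophenyl.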